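Carbonyl Substituent Variation on the Shared Core

The source may report more compounds than this note shows. Statements on the series, on what has been measured and on what is new or still open speak of the compounds shown alone.

For the measured compounds named here, compound 3 `Cc1nc(S(C)(=O)=O)ccc1Oc1ncnc(OC2CCN(C(=O)C3(F)CCC3)CC2)c1F` stands highest of the three numbers so far: in a functional assay on isolated protein for inhibition of Glucose-dependent insulinotropic receptor (Rattus norvegicus), read by HTRF and cAMP accumulation (on this read-out lower numbers stand for smaller maximal responses and higher numbers for larger maximal responses), compound 3 gives 91%. Compound 1 `Cc1nc(S(C)(=O)=O)ccc1Oc1ncnc(OC2CCN(C(=O)OC(C)C)CC2)c1F` gives 77% in this assay, and compound 2 `Cc1nc(S(C)(=O)=O)ccc1Oc1ncnc(OC2CCN(C(=S)OC(C)C)CC2)c1F` gives 47%. The measured steps are a number 14 percentage points higher from compound 1 to compound 3 (beyond the scatter), a number 44 percentage points higher from compound 2 to compound 3 (beyond the scatter) and a number 30 percentage points lower from compound 1 to compound 2 (beyond the scatter).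

Compound 4 `Cc1nc(S(C)(=O)=O)ccc1Oc1ncnc(OC2CCN(C(=O)c3noc(C(C)C)n3)CC2)c1F` is not yet measured. It differs from compound 3 by a group of 8 heavy atoms (5 carbon, 2 nitrogen, 1 oxygen; one five-membered aromatic ring with 3 hetero atoms) in place of a group of 5 heavy atoms (4 carbon, 1 fluorine; one four-membered non-aromatic ring of carbon only), on a carbonyl carbon. Going by the values given here, the one measured step at the same place, on a carbonyl carbon, is a number 14 percentage points higher from compound 1 to compound 3 (beyond the scatter), a modest change; the step on the amine nitrogen in a ring, a number 44 percentage points higher from compound 2 to compound 3 (beyond the scatter), was large. Among the compounds with values here, no measured compound carries an aromatic group on that carbonyl carbon, so the earlier steps only bound the likely size rather than fix the direction. Since compound 3 is the highest number, the room upward is small, and a modest step downward is expected, a number 11 percentage points lower from compound 3 to compound 4 (beyond the scatter). For compound 4 the estimate in this assay is 80%, in the range 60% to 98%.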

Compound 4, largest response reached (reported as efficacy), in percent of the reference or control that the assay uses: 81%
For compound 4 the middle estimate is 1 percentage points below the measured one, and the stated range covers the measured number.
By their numbers in this assay, from the lowest: compound 2; then compounds 1, 4 and 3 (each within the scatter of the next, the first and the last beyond it).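

In this assay, an aromatic ring on the carbonyl carbon is compatible with a maximal response in the range of the two best compounds: 5-isopropyl-1,2,4-oxadiazol-3-yl can replace the fluorocyclobutyl group (a number 10 percentage points lower from compound 3 to compound 4 (within the scatter)) or isopropoxy (a number 4 percentage points higher from compound 1 to compound 4 (within the scatter)) with both steps inside the scatter. For the compounds shown here, compound 2 remains the only low member of the set (a number 34 percentage points higher from compound 2 to compound 4 (beyond the scatter)), so its thiocarbonyl group is still the one change at this end of the molecule with a clear effect on the number. No experimental data on the cause of these steps are available.

The compounds shown leave open whether the isopropyl on the oxadiazole matters, as a methyl or a cyclopropyl in its place would show. They also leave open whether a phenyl ring or a dimethylamino group on the carbonyl carbon would stay in the same range.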